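Swapping bromo for methyl on a thiourea-linked phenyl ring

The source may report more compounds than this note shows. Statements on the series, on what has been measured and on what is new or still open speak of the compounds shown alone.

Compound 3, `NC(=O)c1c(NC(=O)c2ccccc2C(F)(F)F)sc2c1CCN(C(=S)Nc1ccccc1Br)C2`, gives 25500 nM in a functional assay on HL-60 cells (Homo sapiens) for antiproliferative activity, with a stated time of 24 h; a higher number here means a weaker inhibitor, a lower number a stronger inhibitor. Its two measured companions are compound 2, `NC(=O)c1c(NC(=O)c2ccccc2C(F)(F)F)sc2c1CCN(C(=S)Nc1ccccc1Cl)C2`, with 17600 nM, and compound 1, `Cc1ccccc1NC(=S)N1CCc2c(sc(NC(=O)c3ccccc3Cl)c2C(N)=O)C1`, with 22600 nM; all three numbers sit within the usual scatter of one another. Among the measured compounds shown here, the only single-point step measured is a 1.4-fold higher number from compound 2 to compound 3 (0.16 log units; within the scatter). The change to compound 4, `Cc1ccccc1NC(=S)N1CCc2c(sc(NC(=O)c3ccccc3C(F)(F)F)c2C(N)=O)C1`, is methyl in place of bromo on an aromatic carbon. For the measured compounds named here, no measured step covers methyl in place of bromo, and compound 1, which carries the methyl, differs from compounds 2 and 3 at a second place as well. The step expected is therefore a 1.2-fold lower number from compound 3 to compound 4 (0.06 log units; within the scatter), none beyond the scatter. Compound 4 is estimated at 22000 nM, between 10000 nM and 48000 nM.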

Compound 4, half-maximal inhibitory concentration: 25100 nM
Compound 4: the middle estimate sits 1.1-fold (0.06 log units) below what was measured; measured number inside the range.
By their numbers in this assay, from the lowest: compounds 2, 1, 4 and 3 (each within the scatter of the next).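

Methyl, bromo and chloro on this phenyl ring cannot be told apart here: the change from bromo gives a 1.0-fold lower number from compound 3 to compound 4 (0.01 log units; within the scatter) and the change from chloro gives a 1.4-fold higher number from compound 2 to compound 4 (0.15 log units; within the scatter) and both stay within the scatter. At the other varied place, trifluoromethyl and chloro also read alike, with a 1.1-fold higher number from compound 1 to compound 4 (0.05 log units; within the scatter) again within the scatter. Nothing available offers a reason for this flat picture. Still open, going by these compounds, is whether an amine, a carboxylic acid or a longer chain in place of the methyl would shift the number beyond the scatter.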